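Sulfamate series: amine variation on the benzamide ring

The source may hold more compounds than are shown below. What is called first, only, known or untested is meant among the compounds shown, and "the series" means these compounds.

Measured compounds in this set:
compound 1, `NS(=O)(=O)Oc1ccc2c(c1)CN(C(=O)c1cccc(N3CCC(Cc4ccccc4)CC3)c1)CC2` — 41.9%
compound 2, `CCN(Cc1cccc(Br)c1)c1ccc(C(=O)N2CCc3ccc(OS(N)(=O)=O)cc3C2)cc1` — 97.2%
compound 3, `CN(C)CCCN(Cc1ccccc1)c1ccc(C(=O)N2CCc3ccc(OS(N)(=O)=O)cc3C2)cc1` — 61.6%

In an assay on HEK293 cells for inhibition of Steryl-sulfatase (Homo sapiens), tested at 1 uM (a higher number here means a stronger effect of the compound at the concentration tested, a lower number a weaker effect), compound 2 gives 97.2%, the highest of the three numbers. The nearest is compound 3 at 61.6%, a gap beyond the scatter; the furthest is compound 1 at 41.9%, also beyond the scatter. All three share the same core, and the differences lie in the amine on the benzamide ring.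

Compound 4, `CC(C)CCN(CCC(C)C)c1ccc(C(=O)N2CCc3ccc(OS(N)(=O)=O)cc3C2)cc1`, has not yet been measured in this assay. It differs from compound 2 in one place: diisopentylamino in place of (3-bromobenzyl)(ethyl)amino on an aromatic carbon. Among the compounds with values here, no measured pair carries this change, so the size of the step cannot be read from the data. What the set does show is that both other amine variants sit well under compound 2. Because compound 1 gives 41.9% and compound 3 gives 61.6%, a downward step beyond the scatter is expected for compound 4. Compound 4 is estimated at 70%, with a range from 40% to 95%. The expected step in this assay is a number 27.2 percentage points lower from compound 2 to compound 4 (beyond the scatter).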

Compound 4, a percentage reported as inhibition, at one concentration (the size of the read-out at that concentration, not a potency): 90.8%
Compound 4: middle estimate off by 20.8 percentage points, on the low side, and the stated range covers the measured number.
By their numbers in this assay, from the lowest: compound 1; then compound 3; then compounds 4 and 2 (each within the scatter of the next).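

In this assay, within the data shown here, diisopentylamino in place of (3-bromobenzyl)(ethyl)amino on this aromatic carbon, para to a large group, gives a number 6.4 percentage points lower from compound 2 to compound 4 (within the scatter), the first step that can be read directly. For this pair, the read-out stays within the scatter after the six-membered aromatic ring and the bromine of the leaving group are lost, so neither is needed at this position for a read-out of this size. Among these compounds, nothing measured so far accounts for the two groups reading alike.

Both numbers are single-concentration read-outs rather than potencies, so any potency difference between this pair remains unresolved. On these data alone, how much chain length this position needs also stays open, as a smaller group such as diethylamino would test, along with whether a carboxylic acid on the chain is compatible with this read-out.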